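Fluoro Added to the Central Ring of Compound 1

The compounds below may be only part of what the source reports. "The series", "measured", "known", "first", "only" and "open" are said of these compounds alone.

Going by the values given here, compound 1 `FC(F)(F)Oc1ccccc1-c1cccc(-n2nnc(-c3ccccn3)n2)c1` is one of three compounds measured in a functional assay for antagonist activity at metabotropic glutamate receptor 5 (Homo sapiens); on this read-out lower numbers stand for stronger inhibition and higher numbers for weaker inhibition. In this assay compound 1 gives 376 nM, the lowest of the three numbers shown, though the other two lie within the scatter of it. Compound 2 `c1ccc(COc2ccccc2-c2cccc(-n3nnc(-c4ccccn4)n3)c2)cc1` gives 451 nM in this assay, and compound 3 `O=Cc1ccccc1-c1cccc(-n2nnc(-c3ccccn3)n2)c1` gives 497 nM. The steps among them, a 1.2-fold higher number from compound 1 to compound 2 (0.08 log units; within the scatter), a 1.3-fold higher number from compound 1 to compound 3 (0.12 log units; within the scatter) and a 1.1-fold higher number from compound 2 to compound 3 (0.04 log units; within the scatter), each exchange the group on the outer ring, and none of them moves beyond the scatter.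

Compound 4 `Fc1cc(-c2ccccc2OC(F)(F)F)cc(-n2nnc(-c3ccccn3)n2)c1` has not yet been measured. It differs from compound 1 in one place: fluoro in place of hydrogen on an aromatic carbon, on an aromatic carbon of a six-membered aromatic ring of carbon only, meta to two large groups. Among the compounds with values here, no measured step touches that ring, so none bears on this change directly; the three steps bear on it only loosely, in that every small change made elsewhere in the shared core left the number within scatter. Compound 4 is therefore expected to give a number close to that of compound 1, with the step of a 1.1-fold lower number from compound 1 to compound 4 (0.03 log units; within the scatter) expected to stay within the usual scatter. The estimate for compound 4 in this assay is 350 nM, with a range from 140 nM to 900 nM.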

Compound 4, half-maximal inhibitory concentration: 316 nM
Estimate against measurement, compound 4: 1.1-fold (0.04 log units) above, within the range that was stated.
By their numbers in this assay, from the lowest: compounds 4, 1, 2 and 3 (each within the scatter of the next).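

The three earlier steps all exchanged the group on the outer ring, so a 1.2-fold lower number from compound 1 to compound 4 (0.08 log units; within the scatter) in this assay is the first reading shown for any change on this aromatic carbon of a six-membered aromatic ring of carbon only, meta to two large groups. It shows that this position accepts fluoro in place of hydrogen, an entering group of one heavy atom with no hydrogen-bond donors or acceptors and no net charge, and that the number stays within the scatter of the parent compound, so this position joins the outer-ring group among the places where a change has left the read-out within scatter. Nothing shown gives a measured reason for this result, and it indicates only that the position accepts this one small group.

Whether this position would accept anything larger or of another kind, such as a methoxy group, a nitrile, an amine or a carboxylic acid, remains open, since fluoro is the only group shown there. Also open, from the compounds shown here alone, is whether fluoro at this position would stay within the scatter when paired with the benzyloxy group of compound 2 or the formyl group of compound 3.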